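This account rests on a few compounds, and the source may have more. Where it says the series, first, only, none or still open, it means among the compounds named here.

Values in a functional assay on HT-29 cells (Homo sapiens) for antiproliferative activity, read by sulforhodamine B assay, with a stated time of 72 h; on this read-out higher numbers stand for weaker inhibition and lower numbers for stronger inhibition:
- Compound 1 `CC(=O)NC(CO)(CO)CCc1ccc(O)c2ccccc12`: > 80000 nM (a limit)
- Compound 2 `CCCCCCCOc1ccc(CCC(CO)(CO)NC(C)=O)c2ccccc12`: 17600 nM
- Compound 3 `CCCCc1ccc(Oc2ccc(CCC(CO)(CO)NC(C)=O)c3ccccc23)cc1`: > 80000 nM (a limit)

Compound 3 has no number, only a limit, and stands at the limit of > 80000 nM in this assay, at which 2 of the 3 values shown sit. Compound 4 `CCCCc1ccc(COc2ccc(CCC(CO)(CO)NC(C)=O)c3ccccc23)cc1` departs from it by 4-butylbenzyl in place of 4-butylphenyl on an oxygen on an aromatic ring, with 4-butylbenzyl in place of 4-butylphenyl on an oxygen on an aromatic ring.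

Two measured steps change the group at this same place. Replacing the hydrogen gave an at least 4.5-fold lower number from compound 1 to compound 2 (0.65 log units; beyond the scatter), and exchanging heptyl for 4-butylphenyl gave an at least 4.5-fold higher number from compound 2 to compound 3 (0.65 log units; beyond the scatter). The remaining comparison, a step that the two limits leave unreadable from compound 1 to compound 3, adds nothing on size.

The group on this oxygen can therefore move the read-out beyond the scatter, though only in one of the two compounds that carry such a group. For the measured compounds named here, compound 2 gives the sole measured number, 17600 nM, so a modest move towards stronger inhibition is expected. Compound 4 may still return to the limit seen for compound 3. The expected step is an at least 2.6-fold lower number from compound 3 to compound 4 (0.42 log units; beyond the scatter). For compound 4 the estimated value is 30000 nM, with an expected range from 12000 nM to 80000 nM.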

Compound 4, half-maximal inhibitory concentration: 27100 nM
Beside the measured number, compound 4's estimate is 1.1-fold (0.04 log units) above it, within the range that was stated.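

In this assay, 4-butylbenzyl in place of 4-butylphenyl gives an at least 2.9-fold lower number from compound 3 to compound 4 (0.47 log units; beyond the scatter), so a measured number at this position is not confined to the heptyl of compound 2 and an aromatic ring in the group does not by itself leave the read-out at the limit. Compound 4 also holds a readable difference from the hydrogen of compound 1, an at least 2.9-fold lower number from compound 1 to compound 4 (0.47 log units; beyond the scatter), and it cannot be told apart from the heptyl compound, a 1.5-fold higher number from compound 2 to compound 4 (0.19 log units; within the scatter). Of the compounds carrying a group on this oxygen, only compound 3 stays at a limit: the limit of > 80000 nM in this assay, at which 2 of the 4 values shown sit.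

The compounds shown leave open whether the butyl of 4-butylbenzyl matters at all. They also leave open whether a chain longer than heptyl, or an amine or a carboxylic acid in place of that butyl, would move the read-out beyond the level of compound 2 and compound 4.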